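The source may report more compounds than this note shows. Statements on the series, on what has been measured and on what is new or still open speak of the compounds shown alone.

In a functional assay on microsomes from liver (Rattus norvegicus, strain Wistar) for inhibition, with a stated time of 15 min (on this read-out higher numbers stand for weaker inhibition and lower numbers for stronger inhibition), compound 1 (`COc1cc(C2CC(c3cc4ccccc4o3)=NN2C(=O)Nc2ccc(F)cc2)ccc1O`) gives 125000000 nM and compound 2 (`COc1cc(C2CC(c3cc4ccccc4o3)=NN2C(=O)Nc2ccc(C)cc2)ccc1O`) gives 44000000 nM as the lower of the two numbers, which makes compound 2 the stronger inhibitor of this pair. Compound 3 (`COc1cc(C2CC(c3cc4ccccc4o3)=NN2C(=O)Cl)ccc1O`) keeps the shared core and differs from compound 2 on the carbonyl carbon, with chloro in place of (4-methylphenyl)amino (chloro in place of (4-methylphenyl)amino on a carbonyl carbon). Going by the values given here, only one measured step bears on this change, namely a 2.8-fold lower number from compound 1 to compound 2 (0.45 log units; beyond the scatter) with methyl in place of fluoro on an aromatic carbon, and it lies within the group that compound 3 lacks. Among the compounds with values here, no measured compound lacks that group, so the size of the new step is poorly bounded. Compound 3 loses the whole group, so a step larger than a 2.8-fold lower number from compound 1 to compound 2 (0.45 log units; beyond the scatter) is expected, toward a higher number. The expected move is a 3.4-fold higher number from compound 2 to compound 3 (0.53 log units; beyond the scatter) in this assay overall. Compound 3 is estimated at 150000000 nM with 25000000 nM to 800000000 nM as the expected range.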

Compound 3, half-maximal inhibitory concentration: 147000000 nM
The estimate for compound 3 lay 1.0-fold (0.01 log units) above the measured number; low and high end bracket the measured number.
By their numbers in this assay, from the lowest: compound 2; then compounds 1 and 3 (each within the scatter of the next).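

In this assay, chloro in place of (4-methylphenyl)amino on the carbonyl carbon gives a 3.3-fold higher number from compound 2 to compound 3 (0.52 log units; beyond the scatter) and so shows that the lower number of compound 2 depends on the group that leaves. The same exchange starting from the fluoro analogue gives a 1.2-fold higher number from compound 1 to compound 3 (0.07 log units; within the scatter) and thus no readable change, so (4-fluorophenyl)amino and chloro cannot be told apart at this carbon, and the group lowers the number only when it carries the methyl. No measurement at hand offers an explanation for these steps. The compounds shown leave open how a simple amine, a methoxy group or an unsubstituted phenylamino group on the carbonyl carbon would read. They also leave open whether a longer chain or a chloro on the aromatic ring of the amino group would lower the number further than methyl does.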